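Sulfonyl aryl variation on the shared core

The compounds below may be only part of what the source reports. "The series", "measured", "known", "first", "only" and "open" are said of these compounds alone.

Compound 2 `O=C(NCc1ccc(S(=O)(=O)c2ccccc2C(F)(F)F)cc1)c1cc2cnccc2[nH]1` gives 25 nM in a functional assay on A2780 cells (Homo sapiens) for inhibition, read by sulforhodamine B assay, with a stated time of 72 h; a higher number here means a weaker inhibitor, a lower number a stronger inhibitor. For the measured compounds named here, that places compound 2 second highest of the three numbers measured so far: compound 1 `Cc1cccc(S(=O)(=O)c2ccc(CNC(=O)c3cc4cnccc4[nH]3)cc2)c1` gives 4 nM, and compound 3 `O=C(NCc1ccc(S(=O)(=O)c2ccccc2)cc1)c1nc2cnccc2[nH]1`, which carries a different core, gives 5400 nM. Going by the values given here, the only step measured, a 6.3-fold higher number from compound 1 to compound 2 (0.80 log units; beyond the scatter), shows that exchanging the aryl group on the sulfonyl sulfur shifts this assay by a modest amount, beyond the scatter.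

Compound 4 `O=C(NCc1ccc(S(=O)(=O)c2ccc(F)cc2)cc1)c1cc2cnccc2[nH]1` differs from compound 2 at the sulfonyl sulfur: 4-fluorophenyl in place of 2-(trifluoromethyl)phenyl on a sulfonyl sulfur. Among the compounds with values here, only the step from compound 1 to compound 2 bears on this change. Compound 3 differs from the others in its core as well as at the sulfonyl sulfur; its value is not read as a step. Compound 4 carries neither the 3-methylphenyl of compound 1 nor the 2-(trifluoromethyl)phenyl of compound 2, so a number between those of compound 1 and compound 2 is expected, leaning toward compound 1. The estimate for compound 4 in this assay is 8 nM, with a range of 3 nM to 25 nM. The expected step is a 3.1-fold lower number from compound 2 to compound 4 (0.49 log units; beyond the scatter), toward a lower number and of modest size.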

Compound 4, half-maximal inhibitory concentration: 16 nM
Beside the measured number, compound 4's estimate is 2.0-fold (0.30 log units) below it; the range from low to high includes it.
By their numbers in this assay, from the lowest: compound 1; then compounds 4 and 2 (each within the scatter of the next); then compound 3.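

In this assay, exchanging 2-(trifluoromethyl)phenyl for 4-fluorophenyl on a sulfonyl sulfur gives a 1.6-fold lower number from compound 2 to compound 4 (0.19 log units; within the scatter), so these two aryl groups cannot be told apart here, even though the group that leaves has 10 heavy atoms and the group that enters has 7. The 3-methylphenyl of compound 1 now stands apart from both: a 6.3-fold higher number from compound 1 to compound 2 (0.80 log units; beyond the scatter) is joined by a 4.0-fold higher number from compound 1 to compound 4 (0.60 log units; beyond the scatter), which leaves compound 1 with the lowest number among the three compounds on the shared core. No supporting data are available to account for this separation of the 3-methylphenyl group from the other two aryl groups.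

Going by these compounds, compound 1, compound 2 and compound 4 differ in both the substituent and its place on the aryl ring, so it remains open which of the two sets the number in this assay. Also open, on these data alone, is how this position responds to an aryl ring carrying an amine or a carboxylic acid, and whether 3-fluorophenyl would track with 3-methylphenyl or with 4-fluorophenyl.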